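The compounds below may be only part of what the source reports. "The series", "measured", "known", "first", "only" and "open" are said of these compounds alone.

Measured compounds:
Compound 1 `C=C1CCCC(C)(C)C1(O)CC/C(C)=C/CC[C@]1(C)CC[C@@H]([C@@H](C)C(=O)OC)OO1` gives > 17500 nM in a functional assay on HCC 2998 cells (Homo sapiens) for inhibition (a higher number here means a weaker inhibitor of growth, a lower number a stronger inhibitor of growth), which is a limit of the assay and not a number.
Compound 2 `C=C1CCC[C@H]2[C@](C)(CC[C@]3(C)CC[C@H]([C@@H](C)C(=O)O)OO3)[C@@H](C)CC[C@]12C` gives 1550 nM in this assay.
Compound 3 `CC1=C(CC/C(C)=C/CC[C@@]2(C)CC[C@H]([C@H](C)C(=O)O)OO2)C(C)(C)CCC1` gives > 5000 nM in this assay, which is a limit of the assay and not a number.

Within the data shown here, compound 2 is therefore the only member of the set with a measured number in this assay. Compound 1 sits at the limit of > 17500 nM in this assay, at which 1 of the 3 values shown sits. Compound 3 sits at the limit of > 5000 nM in this assay, at which 1 of the 3 values shown sits. Among the measured compounds shown here, no step between measured compounds differs in a single place, so no measured step is available to calibrate the change that leads to compound 4 `C=C1CCC[C@H]2[C@](C)(CC[C@]3(C)CC[C@@H]([C@@H](C)C(=O)O)OO3)[C@@H](C)CC[C@]12C`.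

From compound 2 to compound 4 the change is the two compounds have the same atoms and bonds and differ only in configuration as drawn: 1 of 7 stereo elements differ; a stereocentre at a saturated ring carbon is drawn R in compound 2 and S in compound 4. For the measured compounds named here, with no measured stereochemical step, the size of the effect is open; the working expectation is a step in the direction of weaker inhibition of growth in this assay, of a size that may be modest and could remain within the usual scatter, but with a wide band either way.

Compound 4 is estimated at 3000 nM, with a range from 800 nM to 12000 nM. The step this estimate implies is a 1.9-fold higher number from compound 2 to compound 4 (0.29 log units; within the scatter), expected rather than measured.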

Compound 4, concentration for 50% growth inhibition: 1030 nM
The estimate for compound 4 lay 2.9-fold (0.46 log units) above the measured number, within the range that was stated.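

In this assay, the series now has its first step that differs in one place, and it reads a 1.5-fold lower number from compound 2 to compound 4 (0.18 log units; within the scatter), so drawing this stereocentre at a saturated ring carbon as R or S gives no difference that can be told apart from the scatter. Nothing else varies within this pair, which makes the comparison a direct reading of this one position: the fact that compounds 2 and 4 differ only in the configuration as drawn. Both configurations give a measured number in this assay, so this position tolerates either drawing, a statement that holds only for this pair and for this single stereocentre among the 7 stereo elements.

Compounds 1 and 3 do not differ from compound 2 or compound 4 in one place, so the steps to them cannot be read, and what they show are limits of the assay and not numbers. On these data alone, it remains open whether the same tolerance of either configuration holds at the other stereo elements, or when the carboxylic acid shared by compound 2 and compound 4 gives way to an amide or a primary alcohol.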